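The source may report more compounds than this note shows. Statements on the series, on what has been measured and on what is new or still open speak of the compounds shown alone.

In a functional assay on A549 cells (Homo sapiens) for cytotoxicity, read by MTT assay, with a stated time of 72 h (a lower number here means a stronger inhibitor, a higher number a weaker inhibitor), compound 3 `O=C1c2c[n+]([O-])c3ccccc3c2C(=O)c2c1c1ccccc1n2Cc1cn(C[C@@H](O)CO)nn1` gives 390 nM. Compound 1 `O=C1c2c[n+]([O-])c3ccccc3c2C(=O)c2c1c1ccccc1n2CCCCN1CCNCC1` gives 540 nM, and compound 2 `O=C1c2c[n+]([O-])c3ccccc3c2C(=O)c2c1c1ccccc1n2CCCCN1CCCCC1` gives 150 nM. The data show a 1.4-fold lower number from compound 1 to compound 3 (0.14 log units; within the scatter), so those two cannot be separated, while a 2.6-fold higher number from compound 2 to compound 3 (0.41 log units; beyond the scatter) marks a real gap. Compound 4 `O=C1c2c[n+]([O-])c3ccccc3c2C(=O)c2c1c1ccccc1n2CCCN1CCC(O)CC1` differs from compound 3 as follows: 2-(4-hydroxypiperidin-1-yl)ethyl in place of 1-(2,3-dihydroxypropyl)-1H-1,2,3-triazol-4-yl on a saturated chain carbon bound to an aromatic nitrogen. The closest guides are the chains ending in a six-membered non-aromatic ring, where a 3.6-fold lower number from compound 1 to compound 2 (0.56 log units; beyond the scatter) shows how far one ring change can move the number, though neither ring matches the new group exactly. A slightly lower number, with no step beyond the scatter, is expected in this assay, as an estimated 1.6-fold lower number from compound 3 to compound 4 (0.19 log units; within the scatter). Compound 4 is therefore expected at 250 nM, within an estimated range of 100 nM to 600 nM.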

Compound 4, half-maximal inhibitory concentration: 350 nM
Compound 4: the middle estimate sits 1.4-fold (0.15 log units) below what was measured; the range from low to high includes it.
By their numbers in this assay, from the lowest: compound 2; then compounds 4, 3 and 1 (each within the scatter of the next).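

In this assay, a large change at this position, from the triazole group to 2-(4-hydroxypiperidin-1-yl)ethyl, gives a 1.1-fold lower number from compound 3 to compound 4 (0.05 log units; within the scatter), so losing the five-membered aromatic ring and the defined stereocentre produces no separable difference. Compound 4 also cannot be separated from compound 1, with a 1.5-fold lower number from compound 1 to compound 4 (0.19 log units; within the scatter), whereas a 2.3-fold higher number from compound 2 to compound 4 (0.37 log units; beyond the scatter) leaves compound 2 apart from both. Nothing available explains these numbers. The gap to compound 2 combines a hydroxyl group with a shorter chain, so a plain piperidine on the chain of compound 4 would be needed to separate the two changes.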